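The source may report more compounds than this note shows. Statements on the series, on what has been measured and on what is new or still open speak of the compounds shown alone.

Of the compounds shown here, two built on one shared core have been tested for their ability to slow the growth of a kidney-cancer cell line. Compound 1, `ClCc1cccc(Cn2cnc3nc(Cl)nc(Cl)c32)c1`, gives 1860 nM in a functional assay on CAKI-1 cells (Homo sapiens) for cytotoxicity, read by sulforhodamine B assay, with a stated time of 48 h; a lower number here means a stronger inhibitor of growth, a higher number a weaker inhibitor of growth. Compound 2, `ClCc1ccccc1Cn1cnc2nc(Cl)nc(Cl)c21`, gives 19500 nM in this assay. Of these two numbers, compound 2 has the higher one, and its gap to compound 1 lies beyond the usual scatter, so compound 2 is the weaker inhibitor of growth of the pair. The two differ in their aromatic side chain, and no single-step comparison between them is available.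

Compound 3, `ClCc1ccccc1Cn1cnc2ncnc(Cl)c21`, has not yet been measured. It differs from compound 2 in one place: hydrogen in place of chloro on an aromatic carbon. The core of compound 3 therefore carries one chloro group where compound 2 carries two. For the measured compounds named here, no measured pair shows what this loss does on this core, so the direction of the step is open. The step of a 1.5-fold higher number from compound 2 to compound 3 (0.19 log units; within the scatter) is expected to be small, at or only slightly beyond the scatter toward a higher number. Compound 3 is thus estimated at 30000 nM, with a range from 8000 nM to 100000 nM.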

Compound 3, concentration for 50% growth inhibition: 2340 nM
Beside the measured number, compound 3's estimate is 13-fold (1.11 log units) above it; measured number outside the range, below it.
By their numbers in this assay, from the lowest: compounds 1 and 3 (each within the scatter of the next); then compound 2.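

In this assay, for the compounds shown here, an 8.3-fold lower number from compound 2 to compound 3 (0.92 log units; beyond the scatter) gives the first single-change comparison on this core. It shows that the chloro group on the aromatic carbon between two ring nitrogen atoms is not needed for growth inhibition in these cells, since compound 3, which carries only hydrogen there, is the stronger inhibitor of this pair. Nothing shown here accounts for this gain in strength.

On these data alone, this single step covers only one position and one side chain, so it remains open whether the same swap of chloro for hydrogen would lower the number of compound 1 as well, or what removing the remaining chloro group of compound 3 would do. Also open, as far as these compounds go, is how other groups on the same carbon would compare, such as an amine or a methoxy group, which could show whether hydrogen itself matters here or whether the chloro group is simply the poorer choice among many.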